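The compounds below may be only part of what the source reports. "The series", "measured", "known", "first", "only" and "open" are said of these compounds alone.

Measured so far in a functional assay on HL-60 cells (Homo sapiens) for cytotoxicity, read by WST assay, with a stated time of 48 h; a higher number here means a weaker inhibitor, a lower number a stronger inhibitor: compound 1 `COc1cc(C(c2ccc(O)c(OC)c2)[C@@H](C)[C@@H](C)CO)ccc1O` gives > 100000 nM, which is a limit of the assay rather than a number. Compound 2 `COc1cc(C(c2ccc(O)c(OC)c2)[C@@H](C)C(C)C)ccc1O` gives 20000 nM. Compound 3 `CCCCCCCC[C@H](C(C)C)C(c1ccc(O)c(OC)c1)c1ccc(O)c(OC)c1` gives 3700 nM.

Compound 1 therefore stands at the top of the numbers shown, known only through (the limit of > 100000 nM in this assay, at which 1 of the 3 values shown sits). Compound 4 `COc1cc(C(c2ccc(O)c(OC)c2)[C@H](CO)C(C)C)ccc1O` holds the same atoms as compound 1, joined differently: 1-(hydroxymethyl)-2-methylpropyl in place of 2-(hydroxymethyl)-1-methylpropyl on a saturated chain carbon bound to two aromatic carbons. For the measured compounds named here, the only measured step touching this part of the shared core is an at least 5.0-fold lower number from compound 1 to compound 2 (0.69 log units; beyond the scatter), where the hydroxy disappears entirely. Compound 4 keeps its hydroxy, so that step bears on it only loosely. Compound 4 is expected to show an at least 1.2-fold lower number from compound 1 to compound 4 (0.09 log units; that floor lies within the scatter), within the scatter or at most modest toward a lower number. Compound 4 is accordingly estimated at 80000 nM, with a range from 30000 nM to 300000 nM.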

Compound 4, half-maximal inhibitory concentration: > 100000 nM
Compound 4 was reported as a limit (the forecaster's own chance of this, stated with the estimate: 45%); at least 1.2-fold (0.09 log units) between middle value and limit.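

Moving the hydroxy into the 1-(hydroxymethyl)-2-methylpropyl group leaves compound 4 at a limit of this assay, as compound 1 is, so the step between them cannot be read: the limit of > 100000 nM in this assay, at which 2 of the 4 values shown sit. The new position therefore does not rescue the hydroxy-bearing chain: the record shows an at least 5.0-fold higher number from compound 2 to compound 4 (0.69 log units; beyond the scatter), and also an at least 27-fold higher number from compound 3 to compound 4 (1.43 log units; beyond the scatter). Among these four compounds, only the two without a hydroxy give a number rather than a limit.

Still open, from the compounds shown here alone, is how an amine or a carboxylic acid on this chain would read in this assay.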